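Moving a Piperidine Attachment: Plasma Half-Life of Compound 3

The source may report more compounds than this note shows. Statements on the series, on what has been measured and on what is new or still open speak of the compounds shown alone.

Measured so far in an ADME assay on a cell-free system (plasma, Mus musculus) for metabolic stability, read by LC-MS, tested at 2 uM; on this read-out higher numbers stand for a longer-lived compound and lower numbers for a shorter-lived compound:
- Compound 1 `CC(=O)N1CCC(c2ccc3c(c2)oc(=O)n3C(=O)NCCCCc2ccccc2)CC1`: 0.5 h
- Compound 2 `CC(C)CNC(=O)n1c(=O)oc2cc(C3CCCCN3C)ccc21`: 0.5 h

Level with compound 1, compound 2 stands at 0.5 h, so the two values show no gap. The next compound to be tested is compound 3 `CC(C)CNC(=O)n1c(=O)oc2cc(C3CCCN(C)C3)ccc21`. It has the same atoms as compound 2, joined differently: 1-methylpiperidin-3-yl in place of 1-methylpiperidin-2-yl on an aromatic carbon. Put simply, 1-methylpiperidin-3-yl takes the place of 1-methylpiperidin-2-yl on an aromatic carbon. These are isomers, which means that nothing is added or removed and only the connection changes.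

For the measured compounds named here, no measured pair here differs in just one place, so the data give no direct guide to this change. Going by the values given here, the only anchors are compound 1 at 0.5 h and compound 2 at 0.5 h. In this assay, the expectation is therefore no shift in either direction beyond the scatter. The estimated step is no change at the digits printed from compound 2 to compound 3 (within the scatter). For compound 3, the expected value is 0.5 h, with an estimated range of 0.25 h to 1.1 h.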

Compound 3, half-life in the Mus musculus assay: 0.833 h
The estimate for compound 3 lay 1.7-fold (0.22 log units) below the measured number; the range from low to high includes it.
By their numbers in the Mus musculus assay, from the lowest: compounds 1, 2 and 3 (each within the scatter of the next).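

For the compounds shown here, this is the first step that changes a single place, and it shows that the attachment point of the ring can be moved without a clear effect on lifetime in plasma. In the Mus musculus assay, putting 1-methylpiperidin-3-yl in place of 1-methylpiperidin-2-yl on an aromatic carbon gives a 1.7-fold higher number from compound 2 to compound 3 (0.22 log units; within the scatter), so the two isomers cannot be told apart on this read-out. In a physicochemical assay for solubility, read by HPLC, in phosphate buffer, measured as kinetic solubility, with a stated time of 1 h, at pH 7.4, tested at 250 uM (a higher number here means a more soluble compound, a lower number a less soluble compound), compound 2 gives 190000 nM. In the physicochemical assay compound 3 gives > 250000 nM, and this reading is a limit of the assay, not a number. In the physicochemical assay the same change gives an at least 1.3-fold higher number from compound 2 to compound 3 (0.11 log units; that floor lies within the scatter), so this step is only a floor and does not separate the two isomers either: the limit of > 250000 nM in the physicochemical assay, at which 1 of the 2 values shown sits.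

The compounds shown leave open whether a different group at this place, such as a primary amine or a carboxylic acid in place of the 1-methylpiperidine ring, would move the half-life beyond the scatter. In the physicochemical assay they also leave open how far compound 3 reaches past its limit, and so how large the true step from the other isomer is.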